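Methoxy for methyl on the aryl group of compound 1

The source may hold more compounds than are shown below. What is called first, only, known or untested is meant among the compounds shown, and "the series" means these compounds.

Compound 1 `Cc1ccc(-c2nc3c(c(-c4ccccc4)nn3-c3ccccc3)c(-c3ccc(O)cc3)c2C#N)cc1` is measured in a functional assay on CCRF-CEM cells (Homo sapiens) for antiproliferative activity, read by resazurin assay, with a stated time of 72 h (a higher number here means a weaker inhibitor, a lower number a stronger inhibitor), at 13400 nM, the lowest of the three numbers recorded in this series, with both other compounds standing beyond the scatter above it. Compound 2 `COc1cc(-c2c(C#N)c(-c3ccco3)nc3c2c(-c2ccccc2)nn3-c2ccccc2)ccc1O` gives 36500 nM in this assay, and compound 3 `COc1cc(-c2c(C#N)c(-c3cccs3)nc3c2c(-c2ccccc2)nn3-c2ccccc2)ccc1O` gives 37300 nM. Going by the values given here, the only single-change step among the measured compounds is a 1.0-fold higher number from compound 2 to compound 3 (0.01 log units; within the scatter), a swap at a different site from the change considered here. Compound 4 `COc1ccc(-c2nc3c(c(-c4ccccc4)nn3-c3ccccc3)c(-c3ccc(O)cc3)c2C#N)cc1` differs from compound 1 by methoxy in place of methyl on an aromatic carbon. Among the compounds with values here, no measured step touches this group, so there is nothing to set a direction or a size against; the one step that does exist is itself within the scatter. The expectation for this assay is therefore a step of about a 1.0-fold lower number from compound 1 to compound 4 (0.01 log units; within the scatter), meaning no movement beyond the scatter in either direction. Compound 4 is estimated at 13000 nM in this assay, with a range from 5500 nM to 32000 nM.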

Compound 4, half-maximal inhibitory concentration: 6700 nM
Estimate against measurement, compound 4: 1.9-fold (0.29 log units) above; the range from low to high includes it.
By their numbers in this assay, from the lowest: compounds 4 and 1 (each within the scatter of the next); then compounds 2 and 3 (each within the scatter of the next).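

In this assay, the group para to a large group now has a measured step of its own, a 2.0-fold lower number from compound 1 to compound 4 (0.30 log units; within the scatter). Thus 4-methoxyphenyl, which brings one hydrogen-bond acceptor that methyl lacks, can stand in place of 4-methylphenyl on the shared core with no difference that can be told from the scatter. No evidence bears on why the step has this size.

Still open, going by these compounds, is whether another group at this place, such as an amine, a carboxylic acid or a longer alkoxy chain, would give a step beyond the scatter. Compounds 2 and 3 differ from compound 1 and compound 4 in more than one place, so they leave open whether the same exchange would give a similar step in their setting.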